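The source may report more compounds than this note shows. Statements on the series, on what has been measured and on what is new or still open speak of the compounds shown alone.

In a functional assay on MCF7 cells (Homo sapiens) for cytotoxicity, read by MTT assay, with a stated time of 48 h (on this read-out higher numbers stand for weaker inhibition and lower numbers for stronger inhibition), compound 2, of structure `Fc1cccc(Nc2nc(-c3cccc(F)c3)nc3ccc(F)cc23)c1`, gives 48700 nM. Among the compounds with values here, this is the only number measured so far among the compounds considered; the other result is a limit rather than a number. Compound 1, of structure `COc1ccccc1Nc1nc(-c2cccc(F)c2)nc2ccc(F)cc12`, reaches only a limit, > 50000 nM, which is the limit of > 50000 nM in this assay, at which 1 of the 2 values shown sits. Within the data shown here, the single measured step, an at least 1.0-fold lower number from compound 1 to compound 2 (0.01 log units; that floor lies within the scatter), exchanges 2-methoxyphenyl for 3-fluorophenyl on a nitrogen on an aromatic ring and lies within the scatter of repeated measurements. Compound 3, of structure `Fc1cccc(-c2nc(Nc3ccccc3F)c3cc(F)ccc3n2)c1`, differs from compound 2 by 2-fluorophenyl in place of 3-fluorophenyl on a nitrogen on an aromatic ring; the two have the same atoms, joined differently. Among the measured compounds shown here, the one step measured bears on this change only loosely, as it too exchanged groups at the same nitrogen and brought no movement beyond the scatter. No further evidence on this read-out is available. Compound 3 is therefore expected to show no step beyond the scatter, a 1.0-fold higher number from compound 2 to compound 3 (0.01 log units; within the scatter), in this assay. The estimate for compound 3 in this assay is 50000 nM, with a range from 20000 nM to 120000 nM, and a real chance that only a limit is reported again.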

Compound 3, half-maximal inhibitory concentration: > 50000 nM
Compound 3 ended at the assay's limit (the forecaster's own chance of this, stated with the estimate: 50%); the middle value lies on the limit itself.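

In this assay, the exchange of 3-fluorophenyl for 2-fluorophenyl on a nitrogen on an aromatic ring gives an at least 1.0-fold higher number from compound 2 to compound 3 (0.01 log units; that floor lies within the scatter), so this swap between two groups of the same atoms shows no movement that can be told apart from the scatter, although the true size of the step stays hidden behind the limit. Compound 1 and compound 3 both stand at a limit, so the step between them, fluoro in place of methoxy on an aromatic carbon, cannot be read. With the third group on this nitrogen, no compound separates from the limit by more than the scatter, and the limit now holds most of the results: the limit of > 50000 nM in this assay, at which 2 of the 3 values shown sit.

What stays open is whether any group on this nitrogen can bring the number clearly away from the limit in this assay, since only the 2-methoxyphenyl, 3-fluorophenyl and 2-fluorophenyl groups are shown there. From the compounds shown here alone, a pyridine ring, a benzyl group or a phenyl ring carrying a carboxylic acid or a longer amine chain at this nitrogen could answer that, and the true values of compound 1 and compound 3 remain unknown.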